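The compounds below may be only part of what the source reports. "The series", "measured", "known", "first", "only" and "open" are said of these compounds alone.

Working notes on a small set sharing one core, all read in an ADME assay on HEK293 cells (Homo sapiens) for cytotoxicity, read by CCK-8 assay and cell counting, with a stated time of 2 days; a higher number here means a weaker inhibitor, a lower number a stronger inhibitor. Compound 1 `Oc1cccc(-c2cc(-c3ccc(Cl)cc3)nc(-c3ccco3)c2)c1` gives 8190 nM in this assay. Compound 2 `Oc1cccc(-c2cc(-c3ccc(Cl)cc3)nc(-c3cccnc3)c2)c1` gives 39500 nM. Compound 3 `Oc1cccc(-c2cc(-c3ccccc3)nc(-c3ccc(Cl)cc3)c2)c1` gives 11600 nM. Compound 3 therefore holds the second highest of the three numbers: its nearest neighbour is compound 1, reached by a 1.4-fold higher number from compound 1 to compound 3 (0.15 log units; within the scatter), and the furthest is compound 2, reached by a 3.4-fold lower number from compound 2 to compound 3 (0.53 log units; beyond the scatter).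

The next compound, compound 4 `Oc1cccc(-c2cc(-c3ccncc3)nc(-c3ccc(Cl)cc3)c2)c1`, has not yet been run in this assay. Its change from compound 3 is pyridin-4-yl in place of phenyl on an aromatic carbon. The step bearing most directly on it is a 3.4-fold lower number from compound 2 to compound 3 (0.53 log units; beyond the scatter), which accompanied phenyl in place of pyridin-3-yl; read in reverse, pyridin-3-yl in place of phenyl went with a higher number. The step of a 4.8-fold higher number from compound 1 to compound 2 (0.68 log units; beyond the scatter) points the same way, with pyridin-3-yl replacing furan-2-yl, while a 1.4-fold higher number from compound 1 to compound 3 (0.15 log units; within the scatter) left phenyl and furan-2-yl close to each other. Pyridin-4-yl itself has no counterpart among the measured compounds, so the size is uncertain, but a modest rise in number beyond the scatter is expected. The expected step is a 2.4-fold higher number from compound 3 to compound 4 (0.38 log units; beyond the scatter). For compound 4 the estimate in this assay is 28000 nM, with a range from 12000 nM to 65000 nM.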

Compound 4, half-maximal inhibitory concentration: 2890 nM
Beside the measured number, compound 4's estimate is 9.7-fold (0.99 log units) above it, outside the stated range (below it).
By their numbers in this assay, from the lowest: compound 4; then compounds 1 and 3 (each within the scatter of the next); then compound 2.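

Pyridin-4-yl in place of phenyl on this aromatic carbon, next to the ring nitrogen, gives a 4.0-fold lower number from compound 3 to compound 4 (0.60 log units; beyond the scatter) in this assay and so shows that a nitrogen in this ring does not of itself go with a higher number, as the pyridin-3-yl of compound 2 alone had suggested. Where that nitrogen sits within the ring matters more at this position than any other change seen here, with a 14-fold lower number from compound 2 to compound 4 (1.14 log units; beyond the scatter) as the only large step, and the two pyridine isomers fall at opposite ends of the set. The step of a 2.8-fold lower number from compound 1 to compound 4 (0.45 log units; beyond the scatter) completes the picture, since the steps from all three other compounds are beyond the scatter and the pyridin-4-yl compound is therefore the strongest inhibitor of the four in this assay at this stage.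

Still open, as far as these compounds go, is whether pyridin-2-yl, a saturated amine such as piperidin-4-yl or a carboxylic acid on this carbon would read closer to compound 4 or to compound 2, and whether the order holds when the 3-hydroxyphenyl or 4-chlorophenyl group changes. Nothing at hand accounts for the gap between the two pyridine isomers.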